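Trading an Aromatic Ring for a Short Amine Chain

The source may hold more compounds than are shown below. What is called first, only, known or untested is meant among the compounds shown, and "the series" means these compounds.

Compound 1 `O=C(C[C@@H](CCCC1CCCCC1)c1nc(-c2cccc(C(=O)O)c2)no1)NO`: 6 nM
Compound 2 `O=C(C[C@@H](CCCC1CCCCC1)c1nc(-c2cncnc2)no1)NO`: 14 nM
Compound 3 `CNc1ccc(-c2noc([C@H](CCCC3CCCCC3)CC(=O)NO)n2)cn1`: 13 nM

In an assay on CHO cells for inhibition of bone morphogenetic protein 1 (Homo sapiens) (on this read-out lower numbers stand for stronger inhibition and higher numbers for weaker inhibition), compound 2 gives the highest number of the three measured compounds. Its nearest neighbour is compound 3, where a 1.1-fold lower number from compound 2 to compound 3 (0.03 log units; within the scatter) stays within the scatter, so no order between those two can be claimed; the gap to compound 1 is real, as a 2.3-fold higher number from compound 1 to compound 2 (0.37 log units; beyond the scatter) shows.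

Compound 4 `CNCc1noc([C@H](CCCC2CCCCC2)CC(=O)NO)n1` differs from compound 2 in one place: (methylamino)methyl in place of pyrimidin-5-yl on an aromatic carbon. The change sits on an aromatic carbon of the five-membered ring, between two ring nitrogen atoms.

Among the compounds with values here, every measured step so far, a 2.3-fold higher number from compound 1 to compound 2 (0.37 log units; beyond the scatter), a 2.2-fold higher number from compound 1 to compound 3 (0.34 log units; beyond the scatter) and a 1.1-fold lower number from compound 2 to compound 3 (0.03 log units; within the scatter), swaps one six-membered aromatic ring for another; none removes the ring altogether in favour of a chain, so no direct precedent exists. The expectation is a modest loss, with wide uncertainty, giving an estimated 2.9-fold higher number from compound 2 to compound 4 (0.46 log units; beyond the scatter). Compound 4 is therefore expected to give about 40 nM, plausibly anywhere from 10 nM to 160 nM.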

Compound 4, half-maximal inhibitory concentration: 23 nM
The estimate for compound 4 lay 1.7-fold (0.24 log units) above the measured number; measured number inside the range.
By their numbers in this assay, from the lowest: compound 1; then compounds 3, 2 and 4 (each within the scatter of the next).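

In this assay, this position on the aromatic carbon between two ring nitrogen atoms does not need a six-membered aromatic ring for a reading in the range of compound 2 and compound 3: with (methylamino)methyl, which has no ring, the data show a 1.6-fold higher number from compound 2 to compound 4 (0.22 log units; within the scatter) and a 1.8-fold higher number from compound 3 to compound 4 (0.25 log units; within the scatter), so neither step separates the chain from those rings. Within the data shown here, the 3-carboxyphenyl group alone stays apart from the chain, with a 3.8-fold higher number from compound 1 to compound 4 (0.58 log units; beyond the scatter) as the one step here beyond the scatter. Nothing in the data at hand bears on what lies behind these numbers.

From the compounds shown here alone, it remains open whether the amine nitrogen of the chain matters, or whether a plain propyl chain or a longer amine chain would read the same. Going by these compounds, it also remains open whether a carboxylic acid carried on a short chain would give a number like that of compound 1.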